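The compounds below may be only part of what the source reports. "The series", "measured", "known", "first", "only" and "open" are said of these compounds alone.

Compound 1, with the structure `Oc1ccc2[nH]ncc2c1C(c1ccc(-c2cncnc2)cc1)N1CCCCC1`, is the stronger of the two compounds that give a number in an assay for inhibition of protein disulfide-isomerase (Homo sapiens), with a stated time of 1 h; a lower number here means a stronger inhibitor, a higher number a weaker inhibitor. In this assay compound 1 gives 830 nM. Compound 2, with the structure `Oc1c(C(c2ccc(F)cc2)N2CCCCC2)ccc2cncnc12`, has a different core and carries a fluoro group; in this assay compound 2 gives 4860 nM, a weaker result that lies beyond the usual scatter. Compound 3, with the structure `Cc1ccnc(NC(c2ccc3cccnc3c2O)c2c(Cl)cccc2Cl)c1`, is reported only as a limit of this assay rather than as a number, > 40000 nM. Compound 4, with the structure `Oc1ccc2[nH]ncc2c1C(c1ccc(F)cc1)N1CCCCC1`, is not yet measured. It differs from compound 1 in one place: fluoro in place of pyrimidin-5-yl on an aromatic carbon, on an aromatic carbon of a six-membered aromatic ring of carbon only. For the measured compounds named here, no measured pair shows this exact exchange. Going by the values given here, the expectation for the step from compound 1 to compound 4 in this assay is a 3.6-fold higher number from compound 1 to compound 4 (0.56 log units; beyond the scatter), a weakening beyond the scatter, since the only fluoro-bearing compound with a number, compound 2, gives 4860 nM. Compound 4 is therefore estimated at 3000 nM, expected to fall between 1000 nM and 10000 nM.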

Compound 4, half-maximal inhibitory concentration: 350 nM
Compound 4: middle estimate off by 8.6-fold (0.93 log units), on the high side; measured number below the stated range.
By their numbers in this assay, from the lowest: compound 4; then compound 1; then compound 2. At a limit, above all of these: compound 3.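

In this assay the change on an aromatic carbon of a six-membered aromatic ring of carbon only, para to a large group, gives a 2.4-fold lower number from compound 1 to compound 4 (0.38 log units; beyond the scatter) when fluoro replaces pyrimidin-5-yl. A second aromatic ring at this position is therefore not required for activity on this core, and a single fluorine atom, which adds no ring and no hydrogen-bond acceptors, gives the lower number. No earlier pair differed in one place, so this is the first direct reading of a single change among these compounds.

Going by these compounds, whether fluoro itself matters, or simply the loss of the larger ring, stays open, and a chlorine, a methoxy group or an amine at this position would help to separate the two. Nothing measured here explains why fluoro gives the lower number.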